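This account rests on a few compounds, and the source may have more. Where it says the series, first, only, none or still open, it means among the compounds named here.

Going by the values given here, compound 1, `Cc1nc(SCC(=O)Nc2nc(-c3ccc(Cl)cc3)cs2)n(Nc2ccccc2)c1C`, is the one compound of this small set that gives a definite number: in a functional assay on A498 cells (Homo sapiens) for antiproliferative activity, read by sulforhodamine B assay, with a stated time of 48 h (a lower number here means a stronger inhibitor of growth, a higher number a weaker inhibitor of growth), compound 1 gives 10500 nM, so it is a weak inhibitor of growth. Compound 2, `Cc1ccc(Nn2c(SCC(=O)Nc3nc(-c4ccccc4)cs3)nc(C)c2C)cc1`, is recorded only as a limit of the assay, for in this assay compound 2 gives > 100000 nM. Thus (the limit of > 100000 nM in this assay, at which 1 of the 2 values shown sits), and compound 1 stands alone with a measured value against it. Among the compounds with values here, no step between measured compounds that differ in a single place is available, so nothing has yet been established about what any one change does.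

Compound 3, `COc1ccc(Nn2c(SCC(=O)Nc3nc(-c4ccc(Cl)cc4)cs3)nc(C)c2C)cc1`, differs from compound 1 by methoxy in place of hydrogen on an aromatic carbon. With no single-place comparison to lean on, the step from compound 1 to compound 3 is expected to be small, within or only just beyond the usual scatter, with any movement more likely toward weaker inhibition. On that basis compound 3 is estimated at 16000 nM in this assay, within a range of 5000 nM to 60000 nM, which means an expected step of a 1.5-fold higher number from compound 1 to compound 3 (0.18 log units; within the scatter).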

Compound 3, concentration for total growth inhibition: 56500 nM
Compound 3: the middle estimate sits 3.5-fold (0.55 log units) below what was measured, and the stated range covers the measured number.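

In this assay, the methoxy group that enters on the aromatic carbon para to a large group, turning anilino into (4-methoxyphenyl)amino, gives a 5.4-fold higher number from compound 1 to compound 3 (0.73 log units; beyond the scatter). Going by these compounds alone, this is the first single-place comparison in the set, and it shows that this position does not tolerate every change without consequence: the step lies beyond the scatter and points toward weaker inhibition of growth, though it is only modest in size and rests on a single pair. Compound 2 remains a limit of the assay and not a number, and it differs from the other two compounds in more than one place, so it adds no second step at this position: the limit of > 100000 nM in this assay, at which 1 of the 3 values shown sits.

As far as these compounds go, what stays open is whether the loss follows methoxy in particular or any group at this position, since a fluorine, a hydroxyl, an amine or a carboxylic acid in the same place would each separate those readings. Within the data shown here, it also remains open whether methoxy would have the same effect on a compound without the chlorine on the other aromatic ring, and whether any change at this position can give a lower number than the one compound 1 gives.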